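The source may hold more compounds than are shown below. What is called first, only, known or untested is meant among the compounds shown, and "the series" means these compounds.

Of the compounds shown here, three from this series have been measured in a physicochemical assay for lipophilicity, read by HPLC, at pH 7.5; a lower number here means a more polar compound, a higher number a more lipophilic compound. Compound 1, `CCOc1ccccc1-c1ccc(-c2nc3cnccc3c(NC(COC)C(N)=O)c2C#N)cc1`, gives 2.8 in this assay. Compound 2, `CC[C@@H](Nc1c(C#N)c(-c2ccc(-c3ccccc3CO)cc2)nc2cnccc12)C(N)=O`, gives 2.1 in this assay. Compound 3, `CC[C@H](Nc1c(C#N)c(-c2ccc(Br)cc2)nc2cnccc12)C(N)=O`, gives 2.3 in this assay. On these numbers compound 1 stands highest of the three; compound 3 is nearest to it, with a number lower by an amount beyond the scatter, and compound 2 is furthest, lower by an amount also beyond the scatter. No pair among these three differs in only one place, so no single step between measured compounds can be read off.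

Compound 4, `CCOc1ccccc1-c1ccc(-c2nc3cnccc3c(N)c2C#N)cc1`, has not yet been measured in this assay. It differs from compound 1 as follows: hydrogen in place of 1-carbamoyl-2-methoxyethyl on a nitrogen on an aromatic ring. On the evidence available here, nothing ties this particular change to a measured step, so the expectation rests on the position of compound 1 alone. The step from compound 1 to compound 4 is expected to be small and slightly upward, within or just at the edge of the scatter, at a number 0.20 log units higher from compound 1 to compound 4 (within the scatter). Compound 4 is therefore estimated to give 3 in this assay, with a plausible range from 2.4 to 3.6.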

Compound 4, distribution coefficient: 3
The estimate for compound 4 equals the measured number at the digits printed, and the stated range covers the measured number.
By their numbers in this assay, from the lowest: compounds 2 and 3 (each within the scatter of the next); then compounds 1 and 4 (each within the scatter of the next).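

In this assay the exchange of the 1-carbamoyl-2-methoxyethyl on the nitrogen for hydrogen comes to a number 0.20 log units higher from compound 1 to compound 4 (within the scatter) and gives the series its first step that can be read in one place. For the compounds shown here, at this position, then, the whole group can leave the core of compound 1 with no shift beyond the scatter, something the earlier compounds, which differ from one another in more than one place, could not show. Nothing measured here accounts for this result.

A single step on a single background leaves open whether the same exchange would read alike on compound 2 or compound 3. It also leaves open how this nitrogen would read when carrying a longer chain ending in an amine or a carboxylic acid.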